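Removing the methylsulfonyl from compound 1

The compounds below may be only part of what the source reports. "The series", "measured", "known", "first", "only" and "open" are said of these compounds alone.

Compound 1 `CS(=O)(=O)c1ccc(C(=O)Nc2ccc(Cl)c(-c3nnc4c(Cl)cccn34)c2)cc1` gives in a functional assay on MDA-MB-231 cells (Homo sapiens) for antiproliferative activity, read by MTT assay, with stated times of 72 h and 4 h (a lower number here means a stronger inhibitor, a higher number a weaker inhibitor), a value of > 100000 nM, which is a limit of the assay and not a number.
Compound 2 `CS(=O)(=O)c1ccc(C(=O)Nc2ccc(Cl)c(-c3nnc4c(Cl)cccn34)c2)c(Cl)c1` gives in this assay 37200 nM.
Compound 3 `O=C(Nc1ccc(Cl)c(-c2nnc3c(Cl)cccn23)c1)c1ccccc1` has not been measured in this assay.

Compound 1 thus stands at the weak end, known only as a limit (the limit of > 100000 nM in this assay, at which 1 of the 2 values shown sits). Going by the values given here, the single measured step is an at least 2.6-fold lower number from compound 1 to compound 2 (0.42 log units; beyond the scatter), a different change elsewhere on the core, and it does not bear directly on the change followed here. Compound 3 differs from compound 1 by hydrogen in place of methylsulfonyl on an aromatic carbon. Among the compounds with values here, no measured step covers this change. The expected step is a number no higher from compound 1 to compound 3 (the limit leaves the size open), set near no change beyond the scatter, with wide uncertainty. Compound 3 is estimated at 100000 nM, range 30000 nM to 300000 nM, with a fair chance that again only a limit is reported.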

Compound 3, half-maximal inhibitory concentration: 58200 nM
Beside the measured number, compound 3's estimate is 1.7-fold (0.24 log units) above it; the range from low to high includes it.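

In this assay hydrogen in place of methylsulfonyl gives an at least 1.7-fold lower number from compound 1 to compound 3 (0.23 log units; that floor lies within the scatter) and so turns a reading without a number into a measured one. The methylsulfonyl is therefore not needed for a measured value on this scaffold, and compound 3 gives this position a numeric reference. From the compounds shown here alone, the true size of the step stays unknown because compound 1 is only a limit of the assay: the limit of > 100000 nM in this assay, at which 1 of the 3 values shown sits.

Going by these compounds, whether an amine, a carboxylic acid or a methoxy group at this place would shift the number remains open. Also open, on these data alone, is whether chloro in place of hydrogen on the phenyl of compound 3 would lower it.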